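The compounds below may be only part of what the source reports. "The series", "measured", "known", "first", "only" and "open" are said of these compounds alone.

Compound 1 `CC(C)(N)C(=O)N[C@H](COCc1cc(Cl)cc(Cl)c1)c1nnnn1CCOC(=O)NCCCCO`: 6.75 nM
Compound 2 `CC(C)(N)C(=O)N[C@H](COCc1cccc(C(F)(F)F)c1)c1nnnn1CCOC(=O)NCCCCO`: 1.79 nM

Both compounds were measured in a functional assay on cells for inhibition of growth hormone secretagogue receptor type 1 (Homo sapiens), read by FLIPR and calcium flux; a lower number here means that less compound is needed, a higher number that more compound is needed for the effect. Compound 1 gives 6.75 nM and stands as the higher of the two numbers; its nearest neighbour, compound 2, gives 1.79 nM, and the step of a 3.8-fold lower number from compound 1 to compound 2 (0.58 log units; beyond the scatter) lies beyond the scatter. Compound 3 `COc1ccccc1COC[C@@H](NC(=O)C(C)(C)N)c1nnnn1CCOC(=O)NCCCCO` has not yet been measured. It differs from compound 1 in a single place: 2-methoxyphenyl in place of 3,5-dichlorophenyl on a saturated chain carbon bound to an oxygen on a saturated carbon. Among the measured compounds shown here, the only measured step that touches this position is a 3.8-fold lower number from compound 1 to compound 2 (0.58 log units; beyond the scatter), in which the 3,5-dichlorophenyl was likewise exchanged, though for 3-(trifluoromethyl)phenyl rather than 2-methoxyphenyl; it shows that an exchange here produces a modest shift, but it cannot tell which way a 2-methoxyphenyl will move the number. Compound 3 is therefore expected to land near compound 1, with a step of a 1.8-fold higher number from compound 1 to compound 3 (0.25 log units; within the scatter) and a wide range. The estimate for compound 3 in this assay is 12 nM, between 3 nM and 50 nM.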

Compound 3, half-maximal effective concentration: 1.11 nM
For compound 3 the middle estimate is 11-fold (1.03 log units) above the measured one; the whole stated range lies above it.
By their numbers in this assay, from the lowest: compounds 3 and 2 (each within the scatter of the next); then compound 1.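

In this assay the exchange gives a 6.1-fold lower number from compound 1 to compound 3 (0.78 log units; beyond the scatter) and so places a second replacement, 2-methoxyphenyl, on the same side of the 3,5-dichlorophenyl compound as 3-(trifluoromethyl)phenyl. The two replacements are not told apart, since a 1.6-fold lower number from compound 2 to compound 3 (0.21 log units; within the scatter) stays within the scatter, even though 2-methoxyphenyl brings an oxygen and one hydrogen-bond acceptor that 3,5-dichlorophenyl lacks. The earlier pair showed only that this position responds to one exchange, whereas the two steps now show the same direction for two different groups. Nothing given here accounts for that direction. From the compounds shown here alone, it remains open whether the lower numbers follow from losing the two chlorines or from what enters in their place, and how an unsubstituted phenyl, or a phenyl carrying an amine or a carboxylic acid, would read.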